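The source may report more compounds than this note shows. Statements on the series, on what has been measured and on what is new or still open speak of the compounds shown alone.

Series notes. In an ADME assay on MT4 cells (Homo sapiens) for cytotoxicity, read by MTT assay (a higher number here means that more compound is tolerated, a lower number that less compound is tolerated), compound 1 `Cc1cc(C)cc(S(=O)(=O)c2c(C(=O)NCc3ccccc3O)[nH]c3ccc(Cl)cc23)c1` gives 23800 nM. Compound 2 `Cc1cc(C)cc(S(=O)(=O)c2c(C(=O)NCc3ccc(CO)cc3)[nH]c3ccc(Cl)cc23)c1` gives 31100 nM, and the two numbers lie within the scatter of one another. Among the compounds with values here, the only measured step, a 1.3-fold higher number from compound 1 to compound 2 (0.12 log units; within the scatter), put 4-(hydroxymethyl)phenyl in place of 2-hydroxyphenyl on a saturated chain carbon bound to an amide-type nitrogen and moved nothing beyond the scatter. Compound 3 `Cc1cc(C)cc(S(=O)(=O)c2c(C(=O)NCC(=O)NCc3ccccc3O)[nH]c3ccc(Cl)cc23)c1` differs from compound 1 by (2-hydroxybenzyl)carbamoyl in place of 2-hydroxyphenyl on a saturated chain carbon bound to an amide-type nitrogen. Within the data shown here, no measured step covers the entry of a carbamoyl unit at this place; the one step there was flat, so for compound 3 the expectation in this assay is a step of a 1.1-fold higher number from compound 1 to compound 3 (0.02 log units; within the scatter) that stays within the scatter. Compound 3 is accordingly estimated at 25000 nM, with a range from 10000 nM to 60000 nM.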

Compound 3, half-maximal cytotoxic concentration: > 47300 nM
Compound 3 ended at the assay's limit; the forecaster's own chance of this, stated with the estimate: 20%; middle value at least 1.8-fold (0.27 log units) away from the limit.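

In this assay compound 3 stands at a limit of the assay, not at a number: the limit of > 47300 nM in this assay, at which 1 of the 3 values shown sits.

At the saturated chain carbon bound to an amide-type nitrogen, (2-hydroxybenzyl)carbamoyl gives an at least 1.9-fold higher number from compound 1 to compound 3 (0.29 log units; that floor lies within the scatter) and an at least 1.5-fold higher number from compound 2 to compound 3 (0.18 log units; that floor lies within the scatter). Both floors lie within the scatter, so this place accepts the larger group with no fall in the number, but no real rise is established.

As far as these compounds go, the true size of both steps stays open. So does whether an amine or a carboxylic acid at this place would also reach the limit.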